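The source may report more compounds than this note shows. Statements on the series, on what has been measured and on what is new or still open speak of the compounds shown alone.

Working notes on the series, read in a functional assay on U2OS cells (Homo sapiens) for antiproliferative activity, read by MTT assay, with a stated time of 72 h; on this read-out higher numbers stand for weaker inhibition and lower numbers for stronger inhibition. Compound 1 (`O=C(CSc1cccc(O)c1)Nc1ccc2nc(NC(=O)c3ccccc3)sc2c1`) gives > 100000 nM, which is a limit and not a number. Compound 3 (`O=C(CSc1nnc(NC(=O)COc2ccccc2)s1)Nc1ccc(Br)cc1`) gives > 100000 nM, also a limit. That leaves (the limit of > 100000 nM in this assay, at which 2 of the 3 values shown sit), so compound 1 stands at the limit with no measured potency. Among the measured compounds shown here, compound 2 (`O=C(CSc1ncccn1)Nc1ccc2nc(NC(=O)c3ccc(C(F)(F)F)cc3)sc2c1`) is the only compound with a number so far, at 28100 nM.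

Compound 4 (`Cc1cc(C)cc(C(=O)Nc2nc3ccc(NC(=O)CSc4cccc(O)c4)cc3s2)c1`) has not yet been measured in this assay. It differs from compound 1 by 3,5-dimethylphenyl in place of phenyl on a carbonyl carbon. For the measured compounds named here, no measured pair isolates this change, so its size has to be judged without a direct precedent.

In this assay, a small step toward stronger inhibition is expected, or none beyond the scatter, and a second reading at the limit is quite possible. The starting point offers little, because compound 1 gives > 100000 nM, a limit. The value of compound 2 at 28100 nM marks roughly the strong end of what is expected. The estimated step is an at least 1.2-fold lower number from compound 1 to compound 4 (0.09 log units; that floor lies within the scatter). For compound 4 the expected value is 80000 nM, with an estimated range of 25000 nM to 200000 nM.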

Compound 4, half-maximal inhibitory concentration: 2820 nM
Compound 4: middle estimate off by 28-fold (1.45 log units), on the high side, outside the stated range (below it).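

In this assay, 3,5-dimethylphenyl in place of phenyl on a carbonyl carbon whose other neighbour is an amide-type nitrogen gives an at least 35-fold lower number from compound 1 to compound 4 (1.54 log units; beyond the scatter), the first listed step in the series and one well beyond the scatter. This shows that the position is sensitive to the change: two added carbons on an otherwise unchanged aromatic ring are enough to bring the core of compound 1 from no measured potency to a measured value. The step is only a floor and its full size cannot be read, because the value of compound 1 is a limit and not a number: the limit of > 100000 nM in this assay, at which 2 of the 4 values shown sit.

The compounds shown leave open whether a single methyl on the phenyl would give part or all of this step, and whether larger carbon groups such as tert-butyl would extend it. They also leave open how a phenyl carrying an amine or a carboxylic acid would read here, and whether the step holds when the rest of compound 1 is altered.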